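Replacing the 3-hydroxyphenyl group of compound 2

This account rests on a few compounds, and the source may have more. Where it says the series, first, only, none or still open, it means among the compounds named here.

In a functional assay on MDA-MB-231 cells (Homo sapiens) for inhibition (a lower number here means a stronger inhibitor of growth, a higher number a weaker inhibitor of growth), compound 1 (`O=C(/C=C/c1cccc(O)c1)c1cccc(-n2cc(-c3ccccc3)[nH]c2=O)c1`) gives 3860 nM as its reading, and compound 2 (`O=C(/C=C/c1cccc(O)c1)c1cccc(-n2cc(-c3ccc(Cl)cc3)[nH]c2=O)c1`) gives 3350 nM as its reading. Within the data shown here, these two values lie within the scatter of each other, so compound 2 stands level with compound 1 on the only numbers available. Among the measured compounds shown here, the single measured step is a 1.2-fold lower number from compound 1 to compound 2 (0.06 log units; within the scatter) and it concerns chloro in place of hydrogen on an aromatic carbon, not the group exchanged next. It therefore bears on the new change only indirectly.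

Compound 3 (`COc1cc(/C=C/C(=O)c2cccc(-n3cc(-c4ccc(Cl)cc4)[nH]c3=O)c2)ccc1O`) carries 4-hydroxy-3-methoxyphenyl in place of 3-hydroxyphenyl on a double-bonded chain carbon bound to a double-bonded chain carbon. For the measured compounds named here, no measured step tests a change at this place, so the data give no direction for it. The starting point stays compound 2 at 3350 nM as measured. The expected step in this assay is a 1.1-fold lower number from compound 2 to compound 3 (0.05 log units; within the scatter) and no change beyond the scatter is expected. For compound 3 the estimated value is 3000 nM with an expected range from 1000 nM to 9000 nM as its span.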

Compound 3, concentration for 50% growth inhibition: 3870 nM
The estimate for compound 3 lay 1.3-fold (0.11 log units) below the measured number; the range from low to high includes it.
By their numbers in this assay, from the lowest: compounds 2, 1 and 3 (each within the scatter of the next).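

In this assay, 4-hydroxy-3-methoxyphenyl in place of 3-hydroxyphenyl on a double-bonded chain carbon bound to a double-bonded chain carbon gives a 1.2-fold higher number from compound 2 to compound 3 (0.06 log units; within the scatter), so compound 3 stands level with compound 2. Among these compounds, this is the first reading at this place, since the earlier step covered only chloro in place of hydrogen on an aromatic carbon; here a group of 9 heavy atoms with 2 hydrogen-bond acceptors replaces one of 7 heavy atoms with 1 hydrogen-bond acceptor, and the number stays within the scatter. No measurement on hand offers an explanation for this level result.

The pair cannot separate the contribution of the methoxy group from that of the hydroxy group, as the two names differ in both at once, and one exchange gives no trend for this place. Also open, going by these compounds, is how this aromatic ring would read with a dimethylamino group or a carboxylic acid on it, and whether the level result holds with hydrogen in place of the chloro group of compound 3.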